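Quinolinyl amide variant in a sulfonylurea series

The compounds below may be only part of what the source reports. "The series", "measured", "known", "first", "only" and "open" are said of these compounds alone.

Going by the values given here, compound 3 `Cc1ncccc1C(=O)NCCC1CCN(S(=O)(=O)NC(=O)NC[C@@H]2C[C@@H]3C=C[C@@H]2C3)CC1` is one of three compounds measured in a functional assay on the whole organism (blood) with Rattus norvegicus as the target, with stated times of 24 h and 1 h, at a dose of 5 mg/kg by the intraperitoneal route; a lower number here means a weaker effect, a higher number a stronger effect of the compound at the dose given. Compound 3 gives 16%, level with compound 2 `Cc1ncccc1C(=O)NCCC1CCN(S(=O)(=O)NC(=O)NC2CCCCC2)CC1`, which gives 16%; these two are together the lowest of the three numbers, and compound 1 `COc1ccc(Cl)cc1C(=O)NCCC1CCN(S(=O)(=O)NC(=O)NC2CCCCC2)CC1` gives 25%. The step of a number 9 percentage points lower from compound 1 to compound 2 (within the scatter) replaced the aryl group on the carbonyl carbon, 2-methylpyridin-3-yl in place of 5-chloro-2-methoxyphenyl. The step of no change at the digits printed from compound 2 to compound 3 (within the scatter) changed only the group on the amide-type nitrogen.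

Compound 4 `O=C(NC[C@@H]1C[C@@H]2C=C[C@@H]1C2)NS(=O)(=O)N1CCC(CCNC(=O)c2cc(Cl)cc3cccnc23)CC1` differs from compound 3 in one place: 6-chloroquinolin-8-yl in place of 2-methylpyridin-3-yl on a carbonyl carbon. Among the compounds with values here, the one measured step that touches the same carbonyl carbon, a number 9 percentage points lower from compound 1 to compound 2 (within the scatter), stayed within the scatter, so exchanging the aryl group there has so far moved the read-out little, and there is no measured example of a larger two-ring aryl group at this position. The change from compound 3 to compound 4 is therefore expected to give a number 6 percentage points higher from compound 3 to compound 4 (within the scatter), not beyond the scatter. Compound 4 is expected to give 22% in this assay, in a range from 8% to 40%.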

Compound 4, a percentage reported as activity, at one dose (the size of the read-out at that dose, not a potency): 35%
Beside the measured number, compound 4's estimate is 13 percentage points below it, and the stated range covers the measured number.
By their numbers in this assay, from the lowest: compounds 2, 3, 1 and 4 (each within the scatter of the next, the first and the last beyond it).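

In this assay, the exchange on the carbonyl carbon whose other neighbour is the amide-type nitrogen gives a number 19 percentage points higher from compound 3 to compound 4 (beyond the scatter), whereas the earlier exchange at this place, a number 9 percentage points lower from compound 1 to compound 2 (within the scatter), stayed inside the usual variation. The aryl group at this place can therefore move the read-out at the dose given, at least when 6-chloroquinolin-8-yl, with two aromatic rings, replaces 2-methylpyridin-3-yl, with one aromatic ring. No measurement shown here bears on why the number rises.

This step brings in the second aromatic ring and the chlorine together, so the compounds shown cannot divide the step between them, and a plain quinolin-8-yl group without the chlorine would be needed to tell them apart. On these data alone, it also remains open whether 6-chloroquinolin-8-yl gives a similar step with the six-membered non-aromatic carbon ring group of compound 2 on the amide-type nitrogen, and how the effect changes at other doses.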